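Swapping trifluoromethylpyridinyl isomers on the shared core

The source may hold more compounds than are shown below. What is called first, only, known or untested is meant among the compounds shown, and "the series" means these compounds.

In a physicochemical assay for solubility, using the shake flask method, with a stated time of 24 h, at pH 2 (a lower number here means a less soluble compound, a higher number a more soluble compound), compound 1 `O=c1ncn(Cc2ccc(F)cc2F)c2ccc(Oc3ncccc3C(F)(F)F)cc12` gives 19 ug/mL, while compound 3 `O=c1ncn(Cc2ccc(F)cc2F)c2ccc(Oc3cccnc3C(F)(F)F)cc12` gives 410 ug/mL, the higher of these two numbers. Compound 2 `COc1ccc2c(c1)c(=O)ncn2Cc1ccc(F)cc1F` reads > 900 ug/mL, which is a limit of the assay.

Compound 4 `O=c1ncn(Cc2ccc(F)cc2F)c2ccc(Oc3ccncc3C(F)(F)F)cc12` has 3-(trifluoromethyl)pyridin-4-yl in place of 2-(trifluoromethyl)pyridin-3-yl on an oxygen on an aromatic ring. Among the measured compounds shown here, the closest precedent is the large isomer swap a 22-fold higher number from compound 1 to compound 3 (1.33 log units; beyond the scatter). The replacement of the aryl group by methyl, an at least 2.1-fold lower number from compound 2 to compound 3 (0.34 log units; beyond the scatter), is a smaller step in the reverse sense. One isomer swap sets no direction, so a large move either way remains possible. The central expected step in this assay is a 1.0-fold lower number from compound 3 to compound 4 (0.01 log units; within the scatter). The estimated value for compound 4 is 400 ug/mL, with an expected range of 90 ug/mL to 1000 ug/mL.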

Compound 4, solubility: 700 ug/mL
Compound 4: middle estimate off by 1.8-fold (0.24 log units), on the low side; measured number inside the range.
By their numbers in this assay, from the lowest: compound 1; then compounds 3 and 4 (each within the scatter of the next). At a limit, above all of these: compound 2.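

In this assay, the second isomer swap shows no separation between 3-(trifluoromethyl)pyridin-4-yl and 2-(trifluoromethyl)pyridin-3-yl on this oxygen (a 1.7-fold higher number from compound 3 to compound 4 (0.23 log units; within the scatter)). Compound 1, with 3-(trifluoromethyl)pyridin-2-yl, now stands apart from both isomers, not just from compound 3 (a 37-fold higher number from compound 1 to compound 4 (1.57 log units; beyond the scatter)). The comparison with the methyl group gives no measured size (an at least 1.2-fold lower number from compound 2 to compound 4 (0.10 log units; that floor lies within the scatter)), as compound 2 reads at a limit: (the limit of > 900 ug/mL in this assay, at which 1 of the 4 values shown sits).

Still open, going by these compounds, is whether an amine or a carboxylic acid in place of trifluoromethyl on the pyridine would keep these readings.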